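Chloro for Methyl on a Series Showing No Effect

The compounds below may be only part of what the source reports. "The series", "measured", "known", "first", "only" and "open" are said of these compounds alone.

Three compounds have been measured:

compound 1, `CCC(C(=O)N1CCN(c2cccc(F)c2)CC1)N1C(=O)CCC1=O`, gives 0% in a functional assay on the whole organism (strain Swiss) with Mus musculus as the target, in the maximal electroshock model, with a stated time of 1 h, at a dose of 100 mg/kg by the intraperitoneal route; a higher number here means a stronger effect of the compound at the dose given, a lower number a weaker effect;
compound 2, `CCC(C(=O)N1CCN(c2ccccc2F)CC1)N1C(=O)CCC1=O`, gives 0%;
compound 3, `CCC(C(=O)N1CCN(c2cccc(C)c2)CC1)N1C(=O)CCC1=O`, gives 0%.

All three share one core and differ only in the group carried on the aromatic ring attached to the amine nitrogen in a ring. Compound 3 stands level with compounds 1 and 2; none of the three shows any effect at the dose used. The steps between them confirm this: no change at the digits printed from compound 1 to compound 2 (within the scatter), no change at the digits printed from compound 1 to compound 3 (within the scatter) and no change at the digits printed from compound 2 to compound 3 (within the scatter).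

Compound 4, `CCC(C(=O)N1CCN(c2cccc(Cl)c2)CC1)N1C(=O)CCC1=O`, has not yet been measured. It differs from compound 3 by chloro in place of methyl on an aromatic carbon. Among the compounds with values here, the closest step already measured is the one from compound 1 to compound 3, where fluoro on an aromatic carbon gave way to methyl at the same place, and that step brought no change. Moving the substituent from one aromatic carbon to another, as in the step from compound 1 to compound 2, likewise brought nothing. Given these results, no step beyond the scatter is expected from compound 3 to compound 4, and the expected step is no change at the digits printed from compound 3 to compound 4 (within the scatter). Compound 4 is therefore estimated to give 0% in this assay, with a range from 0% to 10%.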

Compound 4, a percentage reported as activity, at one dose (the size of the read-out at that dose, not a potency): 0%
Compound 4: the middle estimate sits on the measured number at the digits printed, and the stated range covers the measured number.
By their numbers in this assay, from the lowest: compounds 1, 2, 3 and 4 (each within the scatter of the next).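

In this assay, chloro now joins fluoro and methyl at this place on the aromatic ring, and the read-out stays flat: there is no change at the digits printed from compound 3 to compound 4 (within the scatter), and no change at the digits printed from compound 1 to compound 4 (within the scatter). Changing the group and its place on the ring together, with 3-chlorophenyl in place of 2-fluorophenyl, gives the same picture, with no change at the digits printed from compound 2 to compound 4 (within the scatter). Nothing at hand explains why these compounds show no effect.

Going by these compounds, whether a trifluoromethyl group, a methoxy group, an amine or a carboxylic acid at this place on the aromatic ring would produce any effect in this assay remains open. A read-out at one dose and one stated time also leaves open whether these four compounds would differ from one another under other conditions, so the flat result shows only that the substituents compared here make no visible difference under these conditions.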